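A few compounds are considered here, and "the series" means these few. Any claim that something is new, unique, unknown or untested is made for them only; others in the source may bear on it.

Among the compounds with values here, compound 1, `COc1cc(C(=O)N/N=C/c2cccc(F)c2)cc(OC)c1OC`, and compound 2, `COc1ccc(C2OC(c3cc(OC)c(OC)c(OC)c3)=NN2C(C)=O)c(OC)c1`, are the two compounds with numbers so far. In a functional assay on PC-3 cells (Homo sapiens) for antiproliferative activity, read by MTT assay, tested at 5 uM (on this read-out higher numbers stand for a stronger effect at the one concentration tested and lower numbers for a weaker effect), compound 1 gives 64.1%, and in this assay compound 2 gives 92%. Of the two numbers compound 2 holds the higher one, and the gap to compound 1 lies beyond the usual scatter of repeated measurements. The two compounds differ in several places at once, so no single step can be read from them.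

Compound 3, `COc1cc(C2=NN(C(C)=O)C(c3cccc(C(F)(F)F)c3)O2)cc(OC)c1OC`, has not yet been measured. It differs from compound 2 in one place: 3-(trifluoromethyl)phenyl in place of 2,4-dimethoxyphenyl on a saturated ring carbon. Within the data shown here, since no single-change step is known among the measured compounds, the size of the change is uncertain; a modest downward step from compound 2 to compound 3 is expected, probably beyond the scatter but not large. For compound 3 the estimated value in this assay is 75%, with a range from 50% to 95%, meaning an expected step of a number 17 percentage points lower from compound 2 to compound 3 (beyond the scatter).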

Compound 3, a percentage reported as inhibition, at one concentration (the size of the read-out at that concentration, not a potency): 43.6%
Beside the measured number, compound 3's estimate is 31.4 percentage points above it, and the stated range ends above it.
By their numbers in this assay, from the lowest: compound 3; then compound 1; then compound 2.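

On the saturated ring carbon of the five-membered ring, the choice of aromatic group clearly matters in this assay: 3-(trifluoromethyl)phenyl in place of 2,4-dimethoxyphenyl gives a number 48.4 percentage points lower from compound 2 to compound 3 (beyond the scatter), with the rest of the structure unchanged. Within the data shown here, this is the first comparison in the set that isolates a single place, so this position can now be said to respond strongly to such an exchange, at least for this one pair. No measurement presented here accounts for the fall. The two compounds cannot show whether the fall follows from losing the two methoxy groups or from gaining the trifluoromethyl group. On these data alone, how a phenyl ring carrying a single methoxy group, a hydroxyl group or an amine would read at this position also remains open.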